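Chloro in Place of Fluoro on the Aromatic Ring

A few compounds are considered here, and "the series" means these few. Any claim that something is new, unique, unknown or untested is made for them only; others in the source may bear on it.

The measured compounds and their values in an ADME assay on cells (Hepatocyte, Homo sapiens) for metabolic stability, using equilibrium dialysis; a lower number here means slower removal, a higher number faster removal of the compound:
Compound 1, `CC(=O)N[C@@H]1CCC[C@H](C(=O)Nc2cc(-c3cnn4c3CCCC4)c(Cl)cn2)C1`, gives < 1.2 uL/min, which is a limit of this assay rather than a number.
Compound 2, `CC(=O)N[C@@H]1CCC[C@H](C(=O)Nc2cc(-c3cnn4c3CCCCC4)c(Cl)cn2)C1`, gives 4.6 uL/min.
Compound 3, `CC(=O)N[C@@H]1CCC[C@H](C(=O)Nc2cc(-c3cnn4c3CC(C)(C)C4)c(F)cn2)C1`, gives 2.6 uL/min.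

Compound 3 and compound 2 lie within the usual scatter of each other, so no order between them can be read from these two numbers, and compound 1 contributes only a limit (the limit of < 1.2 uL/min in this assay, at which 1 of the 3 values shown sits).

Compound 4, `CC(=O)N[C@@H]1CCC[C@H](C(=O)Nc2cc(-c3cnn4c3CC(C)(C)C4)c(Cl)cn2)C1`, has not yet been measured in this assay. It differs from compound 3 in one place: chloro in place of fluoro on an aromatic carbon.

Among the compounds with values here, the only measured step, an at least 3.8-fold higher number from compound 1 to compound 2 (0.58 log units; beyond the scatter), concerns the size of the non-aromatic ring on the other side of the shared core and not the halogen on the six-membered aromatic ring. Within the data shown here, no measured pair shows the exchange of fluoro for chloro, so there is no direct evidence on which to base a direction. Compound 4 is therefore expected to stay close to compound 3, with a step of a 1.2-fold higher number from compound 3 to compound 4 (0.06 log units; within the scatter) that is expected to lie within the scatter. The estimate for compound 4 in this assay is 3 uL/min, between 1.2 uL/min and 7.5 uL/min.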

Compound 4, intrinsic clearance in a liver preparation (reported as CLH), per the amount of preparation that the assay uses: 3.5 uL/min
For compound 4 the middle estimate is 1.2-fold (0.07 log units) below the measured one; the measured number falls inside the stated range.
By their numbers in this assay, from the lowest: compounds 3, 4 and 2 (each within the scatter of the next). At a limit, below all of these: compound 1.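

In this assay, the exchange of fluoro for chloro on this aromatic carbon, ortho to a large group and para to a large group, is now measured directly, and a 1.3-fold higher number from compound 3 to compound 4 (0.13 log units; within the scatter) shows no readable change for this pair. Within the data shown here, with chloro held in place, replacing the group with the seven-membered non-aromatic ring by the group of compound 4 also stays within the scatter, at a 1.3-fold lower number from compound 2 to compound 4 (0.12 log units; within the scatter), whereas the comparison with the group carrying the six-membered non-aromatic ring, an at least 2.9-fold higher number from compound 1 to compound 4 (0.46 log units; beyond the scatter), lies beyond it, so in these compounds the one step beyond the scatter comes from the ring group and not from the halogen. That step has only a bound for its size, as the figure for compound 1 is a limit of the assay and not a number: the limit of < 1.2 uL/min in this assay, at which 1 of the 4 values shown sits.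

The halogen exchange is shown only with the ring group of compound 3 and compound 4, so it remains open whether fluoro and chloro would also stay this close with the ring groups of compound 1 and compound 2. Also open, as far as these compounds go, is how a bromo, a methoxy or a nitrile on this same aromatic carbon would compare.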